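This account rests on a few compounds, and the source may have more. Where it says the series, first, only, none or still open, it means among the compounds named here.

Measured compounds in the series:
- compound 1, `COc1ccc(-c2cc3ccccc3nc2/C=C/C(=O)c2ccccc2)cc1`: 860 nM
- compound 2, `COc1ccc(-c2cc3ccccc3nc2/C=C/C(=O)c2ccccn2)cc1`: 740 nM
- compound 3, `COc1ccc(-c2cc3ccccc3nc2/C=C/C(=O)c2ccsc2)cc1`: 1060 nM

Notes. In a functional assay on MDA-MB-231 cells (Homo sapiens) for antiproliferative activity, read by XTT assay, with a stated time of 72 h (a higher number here means a weaker inhibitor, a lower number a stronger inhibitor), compound 1 gives 860 nM and stands second highest of the three numbers; its nearest neighbour is compound 2, the furthest compound 3, and both gaps are within the scatter, so no order among the three can be read from these values.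

The unmeasured compound 4 is `COc1ccc(-c2cc3ccccc3nc2/C=C/C(=O)c2c[nH]c3ccccc23)cc1`. It differs from compound 1 in one place: 1H-indol-3-yl in place of phenyl on a carbonyl carbon. All three measured steps concern the same position, the group on the carbonyl carbon whose other neighbour is a double-bonded chain carbon. The steps of a 1.2-fold lower number from compound 1 to compound 2 (0.07 log units; within the scatter), a 1.2-fold higher number from compound 1 to compound 3 (0.09 log units; within the scatter) and a 1.4-fold higher number from compound 2 to compound 3 (0.16 log units; within the scatter) are each within the scatter. Going by the values given here, the group entering in compound 4 is larger than any of the groups exchanged so far and carries a hydrogen-bond donor, which none of the measured groups does, so the measured steps cover it only in part.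

Given that the swaps at this position have so far produced no movement beyond the scatter, compound 4 is expected to land near compound 1, with the step of a 1.1-fold lower number from compound 1 to compound 4 (0.03 log units; within the scatter) expected to stay within the scatter. The estimate for compound 4 in this assay is 800 nM, with a range from 350 nM to 1900 nM, widened to allow for the untested size of the entering group.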

Compound 4, half-maximal inhibitory concentration: > 10000 nM
Compound 4 was reported as a limit; the forecaster's own chance of this, stated with the estimate: 3%; at least 12-fold (1.09 log units) between middle value and limit.
By their numbers in this assay, from the lowest: compounds 2, 1 and 3 (each within the scatter of the next). At a limit, above all of these: compound 4.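

In this assay the group on the carbonyl carbon proves not to be indifferent to every exchange: 1H-indol-3-yl gives an at least 11-fold higher number from compound 1 to compound 4 (1.06 log units; beyond the scatter) as well as an at least 13-fold higher number from compound 2 to compound 4 (1.13 log units; beyond the scatter) and an at least 9.4-fold higher number from compound 3 to compound 4 (0.97 log units; beyond the scatter) while phenyl, pyridin-2-yl and thiophen-3-yl stay within the scatter of one another. Compared with phenyl, the 1H-indol-3-yl group brings a five-membered aromatic ring and a hydrogen-bond donor together, so these compounds cannot separate the two features. Compound 4 stands at > 10000 nM which is a limit of the assay and not a number, so these steps give no exact size: the limit of > 10000 nM in this assay, at which 1 of the 4 values shown sits.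

Going by these compounds, whether the added ring or the hydrogen-bond donor goes with the step stays open, and so does whether any group of this size at the position keeps the values of compounds 1, 2 and 3. A naphthalen-2-yl group, which has two fused rings and no ring hydrogen on nitrogen, or a 1-methylindol-3-yl group on the same carbonyl carbon would bear directly on that question.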